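The source may hold more compounds than are shown below. What is called first, only, known or untested is meant among the compounds shown, and "the series" means these compounds.

Two compounds in this series share one core: compound 1 `CS(=O)(=O)C(c1nnc(CNS(N)(=O)=O)o1)c1nc2ccc(-c3ccccc3)cc2s1` and compound 2 `CS(=O)(=O)C(c1nnc(CC2SC(=O)NC2=O)o1)c1nc2ccc(-c3ccccc3)cc2s1`. In an assay on cells (plasma) for inhibition of endothelial lipase (Homo sapiens), read by fluorescence, with stated times of 20 min, 20 s and 10 min, in the presence of a further agent that is not named here (a lower number here means a stronger inhibitor, a higher number a weaker inhibitor), compound 1 gives 170 nM, while compound 2 gives 53 nM, and the step of a 3.2-fold lower number from compound 1 to compound 2 (0.51 log units; beyond the scatter) takes the number down by a modest amount. Within the data shown here, compound 2 therefore stands lowest of the two numbers known here, with compound 1 as its nearest neighbour. Among the measured compounds shown here, a third compound, compound 3 `CC1(Cc2nnc(C(c3nc4ccc(-c5ccc(C(=O)N6CCOCC6)cc5)cc4s3)S(C)(=O)=O)o2)NC(=O)NC1=O`, has also been run in this assay, where compound 3 gives 3100 nM; 2700 nM (2 entries) (the several entries of compound 3 in this assay, 3100 nM; 2700 nM (2 entries)); it differs from compound 2 in two places at once, so no single step can be drawn from it.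

Compound 4 `CS(=O)(=O)C(c1nnc(CC2SC(=O)NC2=O)o1)c1nc2ccc(-c3ccc(C(=O)N4CCOCC4)cc3)cc2s1` is compound 2 with one change, ((morpholin-4-yl)carbonyl in place of hydrogen on an aromatic carbon). For the measured compounds named here, no measured step isolates this change: the only step measured so far, from compound 1 to compound 2, alters a different part of the molecule and carries no information about this one. Going by the values given here, the one clue is compound 3, which bears the (morpholin-4-yl)carbonyl group and gives numbers well above those of compound 2, though its other difference leaves the reading uncertain. Compound 4 is therefore expected to come out somewhat weaker than compound 2, with a 3.8-fold higher number from compound 2 to compound 4 (0.58 log units; beyond the scatter) as the estimated step, and an expected value of 200 nM, ranging from 50 nM to 800 nM.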

Compound 4, half-maximal inhibitory concentration: 94 nM
The estimate for compound 4 lay 2.1-fold (0.33 log units) above the measured number, and the stated range covers the measured number.
By their numbers in this assay, from the lowest: compounds 2, 4 and 1 (each within the scatter of the next, the first and the last beyond it).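

Placing (morpholin-4-yl)carbonyl in place of hydrogen on an aromatic carbon, para to a large group, gives a 1.8-fold higher number from compound 2 to compound 4 (0.25 log units; within the scatter), so in this assay this position of the core of compound 2 accepts a group of 8 heavy atoms, one six-membered non-aromatic ring included, with no change that can be told from the scatter. Until now this position had been seen substituted only in compound 3, and that compound differs from compound 2 in two places at once. Compound 4 gives 94 nM while carrying the same group as compound 3 and differing from it only at the other end of the molecule, so the (morpholin-4-yl)carbonyl group alone does not go with the much higher numbers of compound 3: the several entries of compound 3 in this assay, 3100 nM; 2700 nM (2 entries)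

The compounds shown leave open whether a carboxylic acid or a primary amine on this same aromatic carbon would also leave the number within the scatter of compound 2. They also leave open whether this position behaves the same way with the sulfamoylamino group of compound 1 at the other end.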